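Cytotoxicity notes on two anilinopyrimidine nitriles and a methyl analogue

The source may hold more compounds than are shown below. What is called first, only, known or untested is meant among the compounds shown, and "the series" means these compounds.

Measured so far in a functional assay on MT4 cells (Homo sapiens) for cytotoxicity, read by MTT assay, with a stated time of 5 days; a higher number here means that more compound is tolerated, a lower number that less compound is tolerated:
compound 1 `N#Cc1ccc(Nc2nccc(Oc3ccc(-c4ccc(C#N)cc4)c(Cl)c3)n2)cc1` gives 31100 nM
compound 2 `COc1cc(Nc2ccnc(Nc3ccc(C#N)cc3)n2)ccc1-c1ccc(C#N)cc1` gives 5260 nM

Compound 2 stands at the lowest of the two numbers shown, so less of it is tolerated by the cells than of compound 1; the gap between the two values is beyond the usual scatter of this assay. Compounds 1 and 2 differ in more than one place, so the two values are simply noted side by side and nothing is drawn from their difference.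

Compound 3 `Cc1cc(Nc2ccnc(Nc3ccc(C#N)cc3)n2)ccc1-c1ccc(C#N)cc1` is the next compound in the series and has not yet been measured in this assay. It differs from compound 2 by methyl in place of methoxy on an aromatic carbon, in words methyl in place of methoxy on an aromatic carbon, at the position ortho to the 4-cyanophenyl group. For the measured compounds named here, no step between measured compounds shows what this change does, so no direction can be read from the data; the expectation is a step from compound 2 to compound 3 of a 1.1-fold higher number from compound 2 to compound 3 (0.06 log units; within the scatter), that is, no change beyond the scatter. The estimate for compound 3 in this assay is 6000 nM, with a range from 2500 nM to 15000 nM.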

Compound 3, half-maximal cytotoxic concentration: 12400 nM
Estimate against measurement, compound 3: 2.1-fold (0.32 log units) below; the range from low to high includes it.
By their numbers in this assay, from the lowest: compound 2; then compound 3; then compound 1.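

Methyl in place of methoxy, ortho to a 4-cyanophenyl group, gives the first change in the series that can be read in one place: in this assay there is a 2.4-fold higher number from compound 2 to compound 3 (0.37 log units; beyond the scatter), a modest step but beyond the scatter. This position is therefore not silent for tolerance by the cells, and here the methyl compound, with one heavy atom and no hydrogen-bond acceptor in the group, is tolerated better than the methoxy compound, with two heavy atoms and one acceptor. Nothing at hand explains the shift.

As far as these compounds go, this single pair cannot separate the loss of the oxygen from the loss of a heavy atom, so it remains open whether the step follows either one or is specific to these two groups. Also open, from the compounds shown here alone, is how a hydroxyl, an amine, an ethyl group or a longer chain at the same position would stand in this assay relative to the methyl and methoxy compounds, and whether the step would hold on a core that differs elsewhere.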